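The source may report more compounds than this note shows. Statements on the series, on what has been measured and on what is new or still open speak of the compounds shown alone.

Compound 1 `Cc1cc(OC(=O)C(C)(C)CCC(CO[N+](=O)[O-])O[N+](=O)[O-])n(-c2ccccc2)n1` carries a 1,2-bis(nitrooxy)ethyl end on its ester side chain. In a functional assay on thoracic aorta (Rattus norvegicus, strain Wistar) for inhibition, in the presence of a further agent that is not named here (a higher number here means that more compound is needed for the effect, a lower number that less compound is needed), compound 1 gives only a limit of > 100000 nM, not a number. Compound 2 `CC(C)(CO[N+](=O)[O-])C(=O)O` is a far smaller acid bearing a single nitrooxy group. In this assay compound 2 also gives only a limit, > 100000 nM. Compound 1 therefore stands at the limit of the assay, a position it shares with the only other value shown (the limit of > 100000 nM in this assay, at which 2 of the 2 values shown sit); nothing among these numbers sets it apart. Compound 3 `Cc1cc(OC(=O)C(C)(C)CCCCO[N+](=O)[O-])n(-c2ccccc2)n1` arises from compound 1 by one change, (hydrogen in place of nitrooxy on a saturated chain carbon bound to two saturated chain carbons), so that the chain end becomes 2-(nitrooxy)ethyl. Among the compounds with values here, no step between measured compounds is available to gauge such a change. With both values shown resting at the same limit (the limit of > 100000 nM in this assay, at which 2 of the 2 values shown sit), there is no measured foothold for expecting a shift beyond the scatter in this assay in either direction. The expected step is accordingly a step that the limit leaves unreadable from compound 1 to compound 3, that is, none beyond the scatter. Compound 3 is thus expected to give about 150000 nM, with a likely range from 50000 nM to 500000 nM, and most probably again only a limit.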

Compound 3, half-maximal effective concentration: > 100000 nM
Compound 3 ended at the assay's limit; the forecaster's own chance of this, stated with the estimate: 80%; the middle value does not contradict the limit.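

Compound 3, like compound 1, rests at a limit and not at a number in this assay, so no step between the two can be read: the limit of > 100000 nM in this assay, at which 3 of the 3 values shown sit.

The compounds shown leave open whether the change from 1,2-bis(nitrooxy)ethyl to 2-(nitrooxy)ethyl alters the concentration needed at all, and how compound 1 and compound 3 rank in this assay.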